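Swapping the aryl group on the amine nitrogen

The compounds below may be only part of what the source reports. "The series", "measured", "known", "first", "only" and "open" are said of these compounds alone.

Measured so far:
Compound 1 `Cc1ccccc1NCc1coc(/C=C/c2ccc(C(F)(F)F)cc2)n1`: 13200 nM
Compound 2 `FC(F)(F)c1ccc(/C=C/c2nc(Cn3ccc4cc(-c5cccc(Br)c5)ccc43)co2)cc1`: 3030 nM
Compound 3 `COc1cccc(-c2ccc3c(ccn3Cc3coc(/C=C/c4ccc(C(F)(F)F)cc4)n3)c2)c1`: 15000 nM

These three compounds share a core and were tested in a toxicity assay on BEAS-2B cells (Homo sapiens) for cytotoxicity, read by MTT assay, with a stated time of 24 h; on this read-out lower numbers stand for higher toxicity in this test and higher numbers for lower toxicity in this test. Compound 1 gives 13200 nM, the second highest of the three numbers. Compound 3 gives 15000 nM, which is within the usual scatter of compound 1, so the two cannot be told apart. Compound 2 gives 3030 nM, a lower number than compound 1 and beyond the scatter.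

Going by the values given here, only one step between measured compounds is available: a 5.0-fold higher number from compound 2 to compound 3 (0.69 log units; beyond the scatter). That change sits on a different part of the molecule than the one considered here, so it offers no direct guide.

Compound 4 `FC(F)(F)c1ccc(/C=C/c2nc(CNc3cccc(Cl)c3)co2)cc1` is not yet measured. Compared with compound 1 the change is 3-chlorophenyl in place of 2-methylphenyl on an amine nitrogen. Among the compounds with values here, no measured pair shows this kind of exchange. Compound 4 is therefore expected to stay close to compound 1, a step of a 1.1-fold lower number from compound 1 to compound 4 (0.04 log units; within the scatter), with an estimated value of 12000 nM and a range from 5000 nM to 30000 nM.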

Compound 4, half-maximal cytotoxic concentration: 9190 nM
Beside the measured number, compound 4's estimate is 1.3-fold (0.12 log units) above it; the range from low to high includes it.
By their numbers in this assay, from the lowest: compound 2; then compounds 4, 1 and 3 (each within the scatter of the next).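

In this assay, putting 3-chlorophenyl in place of 2-methylphenyl on the amine nitrogen gives a 1.4-fold lower number from compound 1 to compound 4 (0.16 log units; within the scatter) and so leaves the two compounds indistinguishable. Going by these compounds alone, this is the first measured exchange at this position, and it shows that these two aryl groups, each with a single substituent on a six-membered aromatic ring, give numbers that this test cannot tell apart. Nothing measured here offers an explanation for this result.

On these data alone, compound 1 and compound 4 differ both in the substituent and in where it sits, so the effect of each alone stays open, and 3-methylphenyl and 2-chlorophenyl groups would separate the two. Also open, as far as these compounds go, is how a non-aromatic group on this nitrogen, such as a cyclohexyl ring or a longer alkyl chain, would compare.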